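Two Methoxy Groups Replace One on the Anilino Ring

The compounds below may be only part of what the source reports. "The series", "measured", "known", "first", "only" and "open" are said of these compounds alone.

In a functional assay on A549 cells (Homo sapiens) for cytotoxicity, read by MTT assay, with a stated time of 72 h (a lower number here means a stronger inhibitor, a higher number a weaker inhibitor), compound 2 `COc1ccc(Nc2nc3ccccc3nc2S(=O)(=O)c2ccc(OC)cc2)cc1` gives 8260 nM. Among the compounds with values here, its only measured neighbour, compound 1 `COc1ccc(S(=O)(=O)c2nc3ccccc3nc2Nc2ccccc2)cc1`, gives 13200 nM in this assay, and the step of a 1.6-fold lower number from compound 1 to compound 2 (0.20 log units; within the scatter) is within the scatter, so compound 2 does not stand apart. Compound 3 `COc1ccc(S(=O)(=O)c2nc3ccccc3nc2Nc2cc(OC)cc(OC)c2)cc1` differs from compound 2 by 3,5-dimethoxyphenyl in place of 4-methoxyphenyl on a nitrogen on an aromatic ring. Within the data shown here, the single measured step, which put methoxy in place of hydrogen on an aromatic carbon, stayed within the scatter; on that basis no step beyond the scatter is expected in this assay for compound 3. Compound 3 is therefore estimated at 9000 nM, with a range from 3000 nM to 30000 nM, an expected step of a 1.1-fold higher number from compound 2 to compound 3 (0.04 log units; within the scatter).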

Compound 3, half-maximal inhibitory concentration: 12700 nM
Compound 3: the middle estimate sits 1.4-fold (0.15 log units) below what was measured, within the range that was stated.
By their numbers in this assay, from the lowest: compounds 2, 3 and 1 (each within the scatter of the next).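

In this assay, replacing 4-methoxyphenyl with 3,5-dimethoxyphenyl on a nitrogen on an aromatic ring gives a 1.5-fold higher number from compound 2 to compound 3 (0.19 log units; within the scatter), and replacing phenyl with 3,5-dimethoxyphenyl there gives a 1.0-fold lower number from compound 1 to compound 3 (0.02 log units; within the scatter). At this position, then, a second methoxy group leaves the number within the scatter, as the first one did, and phenyl, 4-methoxyphenyl and 3,5-dimethoxyphenyl cannot be told apart. No measurement is available that could explain this flat result. Still open, from the compounds shown here alone, is whether a different kind of group on the phenyl ring, such as an amine or a carboxylic acid, would move the number beyond the scatter.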